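Trading methoxy groups for a nitro group on the side chain

A few compounds are considered here, and "the series" means these few. Any claim that something is new, unique, unknown or untested is made for them only; others in the source may bear on it.

For the measured compounds named here, compound 2 `COc1ccc(OC)c(/C=C/C(=O)Nc2cc3c(Nc4ccc(F)c(Cl)c4)ncnc3cc2O[C@H]2CCOC2)c1` is the only member of this small set with a number: in a functional assay on HeLa cells (Homo sapiens) for cytotoxicity, read by MTT assay, with a stated time of 72 h (on this read-out lower numbers stand for stronger inhibition and higher numbers for weaker inhibition), compound 2 gives 26800 nM. Compound 1 `COc1ccc(/C=C/C(=O)Nc2cc3c(Nc4ccc(F)c(Cl)c4)ncnc3cc2OC)c(OC)c1` has no number in this assay: there compound 1 gives "not determined" (no result reported), so no comparison is possible. Compound 3 `O=C(/C=C/c1ccc([N+](=O)[O-])cc1)Nc1cc2c(Nc3ccc(F)c(Cl)c3)ncnc2cc1O[C@H]1CCOC1` changes only the aromatic end of the chain: 4-nitrophenyl in place of 2,5-dimethoxyphenyl on a double-bonded chain carbon bound to a double-bonded chain carbon. Going by the values given here, with no measured step of this kind to lean on, the change is expected to stay roughly within the scatter, with at most a modest shift toward stronger inhibition, so for compound 3 in this assay the estimated value is 20000 nM, within 6000 nM to 70000 nM, an expected step of a 1.3-fold lower number from compound 2 to compound 3 (0.13 log units; within the scatter).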

Compound 3, half-maximal inhibitory concentration: 27400 nM
Compound 3: middle estimate off by 1.4-fold (0.14 log units), on the low side; the range from low to high includes it.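

In this assay, 4-nitrophenyl in place of 2,5-dimethoxyphenyl on a double-bonded chain carbon bound to a double-bonded chain carbon gives a 1.0-fold higher number from compound 2 to compound 3 (0.01 log units; within the scatter), so the two compounds read alike. For the compounds shown here, this is the first measured step at this position, and these two aromatic ends cannot be told apart here. No measurement offered here bears on the reason for this result. Still open, on these data alone, is whether an aromatic end carrying an amine, a carboxylic acid or a longer chain would read differently.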